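Restoring an aromatic arm where a carboxylate left the series weak

A few compounds are considered here, and "the series" means these few. Any claim that something is new, unique, unknown or untested is made for them only; others in the source may bear on it.

Compound 3 `CN(CCNCc1cn(CC(=O)O)nn1)CCNc1ccnc2cc(Cl)ccc12` stands apart from the other two measured analogues in a functional assay on NCI-H460 cells (Homo sapiens) for antiproliferative activity, read by sulforhodamine B assay, with a stated time of 72 h; a lower number here means a stronger inhibitor, a higher number a weaker inhibitor. In this assay compound 3 gives > 200000 nM, which is a limit of the assay and not a number. Compound 1 `CN(CCNCc1cn(-c2ccccc2Cl)nn1)CCNc1ccnc2cc(Cl)ccc12` gives 20000 nM in this assay, and compound 2 `CN(CCNCc1cn(Cc2ccc(Br)cc2)nn1)CCNc1ccnc2cc(Cl)ccc12` gives 12000 nM in this assay; the step between them is a 1.7-fold lower number from compound 1 to compound 2 (0.22 log units; within the scatter). Against both, compound 3 drops off sharply, by an at least 10-fold higher number from compound 1 to compound 3 (1.00 log units; beyond the scatter) and by an at least 16-fold higher number from compound 2 to compound 3 (1.22 log units; beyond the scatter), and it is the one compound of the three sitting at the limit of > 200000 nM in this assay, at which 1 of the 3 values shown sits.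

Compound 4 `CN(CCNCc1cn(Cc2nc3ccccc3[nH]2)nn1)CCNc1ccnc2cc(Cl)ccc12` differs from compound 3 by 1H-benzimidazol-2-yl in place of carboxy on a saturated chain carbon bound to an aromatic nitrogen. For the measured compounds named here, the step that bears most directly on this change is the one from compound 2 to compound 3, where a carboxy took the place of a 4-bromophenyl on the same chain carbon and the number rose by an at least 16-fold higher number from compound 2 to compound 3 (1.22 log units; beyond the scatter); compound 4 now puts an aromatic bicycle back onto that carbon. The step from compound 1 to compound 3, an at least 10-fold higher number from compound 1 to compound 3 (1.00 log units; beyond the scatter), points the same way. Compound 4 is therefore expected to recover most of the ground, with an expected step of an at least 13-fold lower number from compound 3 to compound 4 (1.12 log units; beyond the scatter). The estimate for compound 4 in this assay is 15000 nM, expected to lie between 5000 nM and 60000 nM.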

Compound 4, half-maximal inhibitory concentration: 120000 nM
Estimate against measurement, compound 4: 8.0-fold (0.90 log units) below, outside the stated range (above it).
By their numbers in this assay, from the lowest: compounds 2 and 1 (each within the scatter of the next); then compound 4. At a limit, above all of these: compound 3.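

In this assay, putting an aromatic bicycle back on this saturated chain carbon does not return the series to the level of the two earlier analogues, so an aromatic group there is not enough on its own: the 1H-benzimidazol-2-yl change gives a 10-fold higher number from compound 2 to compound 4 (1.00 log units; beyond the scatter), and the wider change of the whole arm on the aromatic nitrogen gives a 6.0-fold higher number from compound 1 to compound 4 (0.78 log units; beyond the scatter). Against the carboxy group, the change reads as an at least 1.6-fold lower number from compound 3 to compound 4 (0.22 log units; that floor lies within the scatter), so this step alone establishes no real gain over the carboxymethyl arm. Compound 3 is still the only compound held at a limit, which is a limit of the assay and not a number: the limit of > 200000 nM in this assay, at which 1 of the 4 values shown sits.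

The compounds shown leave open whether a plain phenyl or a naphthyl on the same chain carbon would fall nearer compound 2 or compound 4. They also leave open whether the ring nitrogen-hydrogen of the benzimidazole matters, which a methylated benzimidazole or a benzothiophene at this place would begin to test.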